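Cyclohexenyl in place of the fluoro-methyl alkene

A few compounds are considered here, and "the series" means these few. Any claim that something is new, unique, unknown or untested is made for them only; others in the source may bear on it.

Compound 2 `C/C(CN(C[C@H]1Cc2ccccc2CN1)[C@H]1CCCc2cccnc21)=C(\F)CN` stands lowest of the two numbers in a functional assay on CCRF-CEM cells for antagonist activity at C-X-C chemokine receptor type 4 (Homo sapiens), read by calcium flux, with stated times of 25 min and 90 s; a lower number here means a stronger inhibitor, a higher number a weaker inhibitor: compound 2 gives 80 nM, while compound 1 `C/C(CN(C[C@H]1Cc2ccccc2CN1)[C@H]1CCCc2cccnc21)=C(/F)CN` gives 1800 nM. The step of a 23-fold lower number from compound 1 to compound 2 (1.35 log units; beyond the scatter) goes with the fact that compounds 1 and 2 differ only in the configuration as drawn; a change of configuration at the double bond alone moves the number by this much, so the series is sensitive at this part of the molecule.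

Compound 3 `NCC1=C(CN(C[C@H]2Cc3ccccc3CN2)[C@H]2CCCc3cccnc32)CCCC1` carries the change (2-(aminomethyl)cyclohex-1-en-1-yl in place of 3-amino-2-fluoro-1-methylprop-1-en-1-yl on a saturated chain carbon bound to an amine nitrogen). Going by the values given here, no measured step replaces this group; the only step known, from compound 1 to compound 2, swaps the drawn configuration of the same alkene and is large, which says how far the number can move when this part is altered but not in which direction a ring closure will take it. The expectation for compound 3 is therefore a small weakening or no change beyond the scatter, with a step of a 1.9-fold higher number from compound 2 to compound 3 (0.27 log units; within the scatter) in this assay, and an estimated value of 150 nM, in the range 40 nM to 600 nM.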

Compound 3, half-maximal inhibitory concentration: 230 nM
Compound 3: middle estimate off by 1.5-fold (0.19 log units), on the low side, and the stated range covers the measured number.
By their numbers in this assay, from the lowest: compound 2; then compound 3; then compound 1.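

In this assay, putting 2-(aminomethyl)cyclohex-1-en-1-yl in place of 3-amino-2-fluoro-1-methylprop-1-en-1-yl gives a 2.9-fold higher number from compound 2 to compound 3 (0.46 log units; beyond the scatter), and the same replacement, read against the other alkene isomer, gives a 7.8-fold lower number from compound 1 to compound 3 (0.89 log units; beyond the scatter). The position on a saturated chain carbon bound to an amine nitrogen therefore accepts a six-membered carbon ring without fluorine, at a modest cost against compound 2, and compound 3 lies well clear of compound 1, so the ring does not carry the full penalty seen with that isomer. Nothing measured in this set gives a reason for either step.

The ring and the loss of fluorine arrive together in compound 3, so their separate contributions cannot be told apart, and the matching alkene with hydrogen in place of fluorine would be the direct comparison. Also open, going by these compounds, is how a cyclopentenyl ring, a longer chain carrying the amine, or a hydroxyl in place of the amine would read in this assay.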